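One Chlorine Atom in Place of a Larger Group

This account rests on a few compounds, and the source may have more. Where it says the series, first, only, none or still open, it means among the compounds named here.

Compound 1 `Oc1nc2nonc2nc1Nc1ccc(S(F)(F)(F)(F)F)cc1` is tested in an assay on mitochondria from L6 cells (Rattus norvegicus) for activation, with a stated time of 90 min; on this read-out lower numbers stand for an effect already at smaller amounts and higher numbers for an effect only at larger amounts of compound. Within the data shown here, there compound 1 gives 3900 nM, the lower of the two numbers measured so far. Compound 2 `Oc1nc2nonc2nc1Nc1cccc(C(F)(F)F)c1`, which carries a trifluoromethyl group on its aniline ring, gives 13300 nM in this assay; the gap between the two lies beyond the usual scatter, so on these two numbers compound 1 is the more potent. Compound 3 `Oc1nc2nonc2nc1Nc1ccc(Cl)cc1` has not yet been measured. It differs from compound 1 in a single place: one chlorine atom in place of a group of 6 heavy atoms (5 fluorine, 1 sulfur; no ring), on an aromatic carbon. Among the measured compounds shown here, no pair of measured compounds shows what such a swap does here, so there is nothing to lean on beyond the shape of the change itself. The step of a 1.8-fold higher number from compound 1 to compound 3 (0.25 log units; within the scatter) is expected to be a modest rise, perhaps just past the scatter. Compound 3 is estimated at 7000 nM, with a range from 2500 nM to 20000 nM.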

Compound 3, half-maximal effective concentration: 11700 nM
The estimate for compound 3 lay 1.7-fold (0.22 log units) below the measured number, and the stated range covers the measured number.
By their numbers in this assay, from the lowest: compound 1; then compounds 3 and 2 (each within the scatter of the next).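

Among these compounds, compound 3 gives the first direct reading of this position: in this assay, one chlorine atom in place of the group of 6 heavy atoms (5 fluorine, 1 sulfur) brings a 3.0-fold higher number from compound 1 to compound 3 (0.48 log units; beyond the scatter), a modest step. So what this aromatic carbon carries does change the number, and of these two groups the larger one gives the lower number, although with chloro compound 3 still has a measurable value of 11700 nM. No measurement at hand says why the two groups differ.

With only these two groups compared directly at this carbon, the step is a single comparison and not a trend. Going by these compounds, how a methoxy group, an amine or a carboxylic acid would behave at the same carbon stays open.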